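The source may report more compounds than this note shows. Statements on the series, on what has been measured and on what is new or still open speak of the compounds shown alone.

Compound 3, `COc1ccc(N2CCN(Cn3nc(-c4ccc5c(c4)OCCO5)oc3=S)CC2)cc1`, is tested in a functional assay on HepG2 cells (Homo sapiens) for antiproliferative activity, read by MTT assay, with a stated time of 48 h; a higher number here means a weaker inhibitor, a lower number a stronger inhibitor. Against that read-out compound 3 gives only a limit of the assay, > 50000 nM. The same holds for compound 1, `Fc1ccccc1N1CCN(Cn2nc(-c3ccc4c(c3)OCCO4)oc2=S)CC1`: in this assay compound 1 gives the limit > 50000 nM. Between these two the step that the two limits leave unreadable from compound 1 to compound 3 cannot be read, since both ends sit at the limit of > 50000 nM in this assay, at which 2 of the 3 values shown sit. Only compound 2, `S=c1oc(-c2ccc3c(c2)OCCO3)nn1CN1CCN(C(c2ccccc2)c2ccccc2)CC1`, yields a number; in this assay compound 2 gives 9120 nM.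

The next compound, compound 4, `Fc1ccc(N2CCN(Cn3nc(-c4ccc5c(c4)OCCO5)oc3=S)CC2)cc1`, differs from compound 3 by a change of fluoro in place of methoxy on an aromatic carbon. For the measured compounds named here, no measured step tells how fluoro in place of methoxy on an aromatic carbon acts in this assay, and the single step that involves a fluorophenyl, the one from compound 1 to compound 3, stays unreadable between its two limits. What the data offer is therefore thin: two aryl-bearing compounds at the limit and one benzhydryl-bearing compound with a weak number. Compound 4 is expected to stay near the limit as well, with an expected step of a number no higher from compound 3 to compound 4 (the limit leaves the size open) that carries no direction beyond the scatter. The estimate for compound 4 in this assay is 50000 nM, within a range from 20000 nM to 120000 nM.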

Compound 4, half-maximal inhibitory concentration: > 50000 nM
Compound 4 gave a limit, no number; the forecaster's own chance of this, stated with the estimate: 75%; the middle value lies on the limit itself.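

In this assay compound 4 gives > 50000 nM, which is a limit and not a number. Its steps from compound 3 and from compound 1 therefore cannot be read, since all three compounds sit at the same limit: the limit of > 50000 nM in this assay, at which 3 of the 4 values shown sit.

The compounds shown leave open whether 2-fluorophenyl, 4-methoxyphenyl and 4-fluorophenyl differ at all in this assay.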